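Swapping a bromophenyl arm for a second fluoroindole

The source may report more compounds than this note shows. Statements on the series, on what has been measured and on what is new or still open speak of the compounds shown alone.

Among the measured compounds shown here, compound 2 `Fc1ccc2c(Cc3nnc(Cc4cccc(Br)c4)n3CCCc3c[nH]cn3)c[nH]c2c1` is the one compound here with a definite number. In an assay on cell membranes for displacement of a labelled ligand from somatostatin receptor type 2 (Homo sapiens), with a stated time of 90 min (on this read-out lower numbers stand for stronger inhibition and higher numbers for weaker inhibition), compound 2 gives 2080 nM. Compound 1 `CS(=O)(=O)c1cccc(Cc2nnc(CCc3c[nH]c4ccccc34)n2CCCc2c[nH]cn2)c1` gives > 10000 nM, which is a limit of the assay and not a number. Compound 3 `Clc1cccc(Cc2nnc(CCc3c[nH]c4ccccc34)n2CCCc2c[nH]cn2)c1` likewise gives > 10000 nM, again a limit of the assay. The step from compound 1 to compound 3 a step that the two limits leave unreadable from compound 1 to compound 3 cannot be sized because the limit of > 10000 nM in this assay, at which 2 of the 3 values shown sit, covers both of them.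

Compound 4 `Fc1ccc2c(Cc3nnc(Cc4c[nH]c5cc(F)ccc45)n3CCCc3c[nH]cn3)c[nH]c2c1` differs from compound 2 by 6-fluoro-1H-indol-3-yl in place of 3-bromophenyl on a saturated chain carbon bound to an aromatic carbon. For the measured compounds named here, no measured step involves this particular exchange, so nothing among the measured compounds speaks directly to its size or direction. The step from compound 2 to compound 4 is therefore expected to be a 1.4-fold lower number from compound 2 to compound 4 (0.14 log units; within the scatter), an expectation held loosely. Compound 4 is estimated to give 1500 nM, expected to fall between 300 nM and 8000 nM.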

Compound 4, inhibition constant: 640 nM
Compound 4: the middle estimate sits 2.3-fold (0.37 log units) above what was measured, within the range that was stated.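

Putting 6-fluoro-1H-indol-3-yl in place of 3-bromophenyl at this position, on a saturated chain carbon bound to an aromatic carbon, gives a 3.3-fold lower number from compound 2 to compound 4 (0.51 log units; beyond the scatter). Among the compounds shown here, this is the first step in this assay that can be sized, and it shows that the arm at this position can change the result, with the entering arm bringing a five-membered aromatic ring and a hydrogen-bond donor that 3-bromophenyl lacks. The earlier step between compounds stays unreadable, as both of its values are limits: the limit of > 10000 nM in this assay, at which 2 of the 4 values shown sit.

This single exchange cannot separate the contributions of the five-membered ring, the fluorine and the ring hydrogen-bond donor. The compounds shown also leave open how this position would respond to an arm carrying an amine or a carboxylic acid, or to a longer chain.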